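A few compounds are considered here, and "the series" means these few. Any claim that something is new, unique, unknown or untested is made for them only; others in the source may bear on it.

The set shares one core, which carries a phenyl group and a second arm that varies from compound to compound. Compound 1 `Nc1cc(N)c2nc(-c3ccccc3)c(Oc3ccc(F)cc3)nc2c1` bears an aryl ether arm. In a functional assay on SNB-75 cells (Homo sapiens) for inhibition, read by sulforhodamine B assay, with a stated time of 48 h (a higher number here means that more compound is tolerated, a lower number that less compound is tolerated), compound 1 gives only a limit, < 100000 nM. Compound 2 `COc1cc(CNc2nc3cc(N)cc(N)c3nc2-c2ccccc2)cc(OC)c1OC` carries a trimethoxybenzylamine arm, and in this assay compound 2 also gives only a limit, < 50200 nM. Within the data shown here, compound 3 `COc1ccc(CNc2nc3cc(N)cc(N)c3nc2-c2ccccc2)cc1OC` is the one member with a measured number: in this assay compound 3 gives 97700 nM. The other two values stand at a floor, the limit of < 100000 nM in this assay, at which 1 of the 3 values shown sits, and (the limit of < 50200 nM in this assay, at which 1 of the 3 values shown sits), so compound 3 cannot be ranked against them. Among the measured compounds shown here, the only step that can be sized is an at least 1.9-fold higher number from compound 2 to compound 3 (0.28 log units; that floor lies within the scatter), and its floor lies within the scatter.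

Compound 4 `COc1ccc(CNc2nc3cc(N)cc(N)c3nc2-c2ccccc2)cc1` follows from compound 3 by hydrogen in place of methoxy on an aromatic carbon. For the measured compounds named here, the single measured step of this kind, hydrogen in place of methoxy on an aromatic carbon, is an at least 1.9-fold higher number from compound 2 to compound 3 (0.28 log units; that floor lies within the scatter), and it gives no ground to expect a movement beyond the scatter. Compound 4 is therefore expected to sit close to compound 3, with an estimated 100000 nM, between 40000 nM and 250000 nM. The expected step is a 1.0-fold higher number from compound 3 to compound 4 (0.01 log units; within the scatter).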

Compound 4, concentration lethal to 50% of the cells: 72400 nM
Beside the measured number, compound 4's estimate is 1.4-fold (0.14 log units) above it; the measured number falls inside the stated range.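

In this assay, among these compounds, this change now has a measured number at both ends for the first time: a 1.3-fold lower number from compound 3 to compound 4 (0.13 log units; within the scatter). Compound 2, the starting point of the earlier step of this kind, gives a limit and not a number: the limit of < 50200 nM in this assay, at which 1 of the 4 values shown sits. Among the compounds shown here, the pair of compound 3 and compound 4 therefore gives the first step of full size for going from 3,4-dimethoxyphenyl to 4-methoxyphenyl, and at this place, on an aromatic carbon ortho to a methoxy group and meta to a large group, hydrogen in place of methoxy leaves the number within the scatter.

The compounds shown leave open whether a fluorine, a hydroxyl or an amine on this same aromatic carbon would move the number beyond the scatter, and whether the remaining methoxy group of compound 4 could be replaced by hydrogen with as little result. They also leave open how the benzylamine arm ranks against the aryl ether arm of compound 1, which gives only a limit: the limit of < 100000 nM in this assay, at which 1 of the 4 values shown sits.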